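This account rests on a few compounds, and the source may have more. Where it says the series, first, only, none or still open, it means among the compounds named here.

Among the measured compounds shown here, compound 2 `C#CC(=O)N1C(CCCCC)SC[C@@H]1C(=O)OCC` gives 2000 nM in a functional assay on MV cells (Homo sapiens) for inhibition, read by sulforhodamine B assay (a lower number here means a stronger inhibitor, a higher number a weaker inhibitor), the highest of the three numbers measured so far. Compound 1 `C#CC(=O)N1C(C(C)CCC)SC[C@@H]1C(=O)OCC` gives 500 nM in this assay, and compound 3 `C#CC(=O)N1C(C(CC)CCCC)SC[C@@H]1C(=O)OCC` gives 1600 nM. Thus a 4.0-fold higher number from compound 1 to compound 2 (0.60 log units; beyond the scatter) and a 3.2-fold higher number from compound 1 to compound 3 (0.51 log units; beyond the scatter), while a 1.3-fold lower number from compound 2 to compound 3 (0.10 log units; within the scatter), so compound 2 and compound 3 cannot be told apart. Compound 4 `C#CC(=O)N1C(c2ccc(F)cc2)SC[C@@H]1C(=O)OCC` differs from compound 2 in one place: 4-fluorophenyl in place of pentyl on a saturated ring carbon. None of the three measured steps replaces a chain with an aromatic ring; they only vary chains on the same saturated ring carbon, and they show that exchanging one chain for another moves this assay by at most a modest amount, as in a 4.0-fold higher number from compound 1 to compound 2 (0.60 log units; beyond the scatter). The change to compound 4 is of a different kind, so the bearing of those steps is weak. For compound 4 a number near the measured compounds is expected, with a wide margin, so that a 1.7-fold lower number from compound 2 to compound 4 (0.22 log units; within the scatter) is the estimated step. Compound 4 is estimated at 1200 nM in this assay, in the range 250 nM to 6000 nM.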

Compound 4, half-maximal inhibitory concentration: 400 nM
Compound 4: the middle estimate sits 3.0-fold (0.48 log units) above what was measured; the measured number falls inside the stated range.
By their numbers in this assay, from the lowest: compounds 4 and 1 (each within the scatter of the next); then compounds 3 and 2 (each within the scatter of the next).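

At the saturated ring carbon next to the ring nitrogen and the ring sulfur, this assay accepts an aromatic ring as well as a chain: 4-fluorophenyl in place of pentyl gives a 5.0-fold lower number from compound 2 to compound 4 (0.70 log units; beyond the scatter), and in place of 1-ethylpentyl it gives a 4.0-fold lower number from compound 3 to compound 4 (0.60 log units; beyond the scatter). Set against the 1-methylbutyl group, the same kind of change gives a 1.3-fold lower number from compound 1 to compound 4 (0.10 log units; within the scatter), so a branched chain and a fluorinated aromatic ring cannot be told apart at this position, and a chain is not needed there for a number at this level. Nothing available explains why these groups read as they do. Still open, from the compounds shown here alone, is what the fluorine contributes, since a plain phenyl, a pyridine ring or a phenyl bearing an amine or a carboxylic acid could read differently at this carbon. Also open, going by these compounds, is whether the 4-fluorophenyl result holds when the ethoxycarbonyl group gives way to a carboxylic acid or an amide.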